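This account rests on a few compounds, and the source may have more. Where it says the series, first, only, none or still open, it means among the compounds named here.

Compound 1 has the structure `Ic1ccc(Cn2cc(CCCOc3cccc4cccnc34)nn2)cc1`. In an ADME assay on HaCaT cells (Homo sapiens) for inhibition, read by sulforhodamine B assay, with a stated time of 48 h (a higher number here means a weaker inhibitor of growth, a lower number a stronger inhibitor of growth), compound 1 gives > 250 ug/mL, which is a limit of the assay rather than a number. Compound 2 has the structure `Fc1ccc(Cn2cc(CCCOc3cccc4cccnc34)nn2)cc1F` and in this assay compound 2 gives 41.7 ug/mL. Compound 3 has the structure `Clc1ccc(Br)cc1Cn1cc(CCCOc2cccc3cccnc23)nn1` and in this assay compound 3 gives 4.9 ug/mL.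

Among the numbers shown, compound 3 stands lowest; the nearest is compound 2, and the step of an 8.5-fold lower number from compound 2 to compound 3 (0.93 log units; beyond the scatter) lies beyond the scatter. The other steps run the same way: an at least 5.9-fold lower number from compound 1 to compound 2 (0.77 log units; beyond the scatter) and an at least 51-fold lower number from compound 1 to compound 3 (1.70 log units; beyond the scatter).

Compound 4 has the structure `c1ccc(Cn2cc(CCCOc3cccc4cccnc34)nn2)cc1`. It differs from compound 3 in one place: phenyl in place of 5-bromo-2-chlorophenyl on a saturated chain carbon bound to an aromatic nitrogen. Within the data shown here, every step so far has changed the substitution on this same phenyl ring, and each such change moved the number well beyond the scatter, so the step from compound 3 to compound 4 is expected to do the same. Since compound 1 sits at the limit of > 250 ug/mL in this assay, at which 1 of the 3 values shown sits, and compound 2 at 41.7 ug/mL, the unsubstituted phenyl of compound 4 is expected to give a higher number than compound 3.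

For compound 4 the step is estimated as a 12-fold higher number from compound 3 to compound 4 (1.09 log units; beyond the scatter). In this assay compound 4 is therefore expected to give about 60 ug/mL, within a range from 15 ug/mL to 250 ug/mL.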

Compound 4, concentration for 50% growth inhibition: 12.7 ug/mL
Compound 4: the middle estimate sits 4.7-fold (0.67 log units) above what was measured; measured number outside the range, below it.
By their numbers in this assay, from the lowest: compound 3; then compound 4; then compound 2. At a limit, above all of these: compound 1.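

Compound 4 supplies the unsubstituted reference for this position, on a saturated chain carbon bound to an aromatic nitrogen, and it falls inside the series rather than at its high end: the change to phenyl gives a 2.6-fold higher number from compound 3 to compound 4 (0.41 log units; beyond the scatter), but also a 3.3-fold lower number from compound 2 to compound 4 (0.52 log units; beyond the scatter) and an at least 19-fold lower number from compound 1 to compound 4 (1.29 log units; beyond the scatter). Substitution on this ring therefore moves the number in both directions, with the 5-bromo-2-chlorophenyl of compound 3 lowering it relative to phenyl, while the 3,4-difluorophenyl of compound 2 and the 4-iodophenyl of compound 1 raise it, so halogen substitution as such does not lower the number in this set. The value of compound 1 is a limit of the assay and not a number, and the true size of its step stays unknown: the limit of > 250 ug/mL in this assay, at which 1 of the 4 values shown sits.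

The compounds shown do not separate the contribution of the bromo from that of the chloro in the 5-bromo-2-chlorophenyl group of compound 3. They also leave open how this assay would respond to a non-halogen group on this ring, such as a methoxy group or an amine, or to a longer chain between this ring and the rest of the core.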